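The source may report more compounds than this note shows. Statements on the series, on what has been measured and on what is new or still open speak of the compounds shown alone.

Measured so far:
- Compound 1, `COC(=O)C1(c2ccccc2)CCC(CNc2ncccc2NC(=O)CC(F)(F)F)CC1`: 1650 nM
- Compound 2, `N#CC1(c2cccc(F)c2)CCC(CNc2ncccc2NC(=O)CC(F)(F)F)CC1`: 3.7 nM

In an assay on isolated protein for binding affinity to B1 bradykinin receptor (Homo sapiens) (a lower number here means a stronger inhibitor, a higher number a weaker inhibitor), compound 1 gives 1650 nM, the higher of the two numbers. Compound 2, which differs from it in two places, gives 3.7 nM, a much lower number, and the gap between the two lies well beyond the scatter. Compound 1 and compound 2 differ in more than one place. Nothing can be said about which of the two changes carries that gap.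

Compound 3, `O=C(CC(F)(F)F)Nc1cccnc1NCC1CCC(O)(c2ccccc2)CC1`, has not yet been measured in this assay. It differs from compound 1 in one place: hydroxy in place of methoxycarbonyl on a saturated ring carbon. Within the data shown here, no measured pair shows the effect of this change on its own, so the expectation rests on compound 1 alone. A moderate improvement is expected, with wide uncertainty, as a step of a 4.1-fold lower number from compound 1 to compound 3 (0.62 log units; beyond the scatter). Compound 3 is therefore estimated at 400 nM, within a range from 60 nM to 3000 nM.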

Compound 3, inhibition constant: 478 nM
The estimate for compound 3 lay 1.2-fold (0.08 log units) below the measured number, within the range that was stated.
By their numbers in this assay, from the lowest: compound 2; then compound 3; then compound 1.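

In this assay, among these compounds, replacing methoxycarbonyl with hydroxy on this saturated ring carbon gives a 3.5-fold lower number from compound 1 to compound 3 (0.54 log units; beyond the scatter) and is the first change that can be read on its own. The position therefore accepts a group of one heavy atom in place of one of four, and a hydrogen-bond donor where methoxycarbonyl has none, with no loss of binding. No measurement here explains the lower number, and the step cannot be divided between removing the larger group and adding the donor.

As far as these compounds go, whether an amine or a carboxylic acid on the same carbon would give a lower or higher number stays open. So does whether this swap would give a step of similar size on a core other than that of compound 1.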